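A few compounds are considered here, and "the series" means these few. Any claim that something is new, unique, unknown or untested is made for them only; others in the source may bear on it.

Compound 1 `O=C1C=CC(=O)C(c2cc(-c3ccc(C(=O)N4CCCCC4)s3)on2)=C1` and compound 4 `O=C1C=CC(=O)C(c2cc(-c3ccc(C(=O)N4CCCC4)s3)on2)=C1` share one core and differ only in the ring attached to the carbonyl carbon. In a functional assay on A549 cells (Homo sapiens) for cytotoxicity, read by XTT assay, with a stated time of 72 h (a lower number here means a stronger inhibitor, a higher number a weaker inhibitor), compound 1 gives > 30000 nM, which is a limit of the assay rather than a measured number. Compound 2 `COc1ccc(OC)c(-c2cc(-c3ccc(C(=O)NCC4CC4)s3)on2)c1` gives > 30000 nM in this assay, again a limit. Among the compounds with values here, compound 3 `CCN(CC)C(=O)c1ccc(-c2cc(-c3cc(OC)ccc3OC)no2)s1` is the only compound with a numerical result, 11000 nM in this assay. Within the data shown here, the single measured step, an at least 2.7-fold lower number from compound 2 to compound 3 (0.43 log units; beyond the scatter), also alters the group on the carbonyl carbon, but on a different core from that of compound 1, so it bears only loosely on the step at hand. The change to be judged is pyrrolidin-1-yl in place of piperidin-1-yl on a carbonyl carbon. Among the measured compounds shown here, it is a small one, and the one comparable step suggests that such changes on the carbonyl carbon move the number modestly if at all. Since compound 1 sits at the limit of > 30000 nM in this assay, at which 2 of the 3 values shown sit, a modest movement in either direction would most likely leave compound 4 at that limit too. Compound 4 is therefore expected at 30000 nM, with a range from 10000 nM to 60000 nM, which amounts to an expected step of a number no higher from compound 1 to compound 4 (the limit leaves the size open).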

Compound 4, half-maximal inhibitory concentration: > 30000 nM
Compound 4: only a limit was reported; the forecaster's own chance of this, stated with the estimate: 70%; the middle value sits exactly at the limit.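

Compound 1 and compound 4 each give a limit of the assay rather than a number, so no step can be read between them: the limit of > 30000 nM in this assay, at which 3 of the 4 values shown sit.

The compounds shown leave open how the piperidin-1-yl and pyrrolidin-1-yl amides on the shared core truly compare in this assay and whether this change of ring alters the number at all.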